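The source may report more compounds than this note shows. Statements on the series, on what has been measured and on what is new or still open speak of the compounds shown alone.

Measured compounds:
compound 1 `COc1cc2c(cc1OC)C(CC(=O)Nc1cccc(C)c1)CC2`: 41.7%
compound 2 `COc1cc2c(cc1OC)C(CC(=O)Nc1ccccn1)CC2`: 33.3%

In a functional assay on the whole organism (strain Wistar) for inhibition, with Rattus norvegicus as the target, read by paw edema, with a stated time of 24 h, at a dose of 100 mg/kg (a lower number here means less inhibition, a higher number more inhibition at the dose given (going by the name of the read-out)), compound 1 gives 41.7%, and compound 2 gives 33.3%. Compound 2 stands close to compound 1: the step of a number 8.4 percentage points lower from compound 1 to compound 2 (within the scatter) is within the scatter, so neither can be placed above the other. Compound 3 `COc1cc2c(cc1OC)C(CC(=O)Nc1cccnc1)CC2` differs from compound 2 by pyridin-3-yl in place of pyridin-2-yl on an amide-type nitrogen. Within the data shown here, no measured step bears directly on this change; the only measured step, a number 8.4 percentage points lower from compound 1 to compound 2 (within the scatter), swaps a different group and is itself within the scatter. Compound 3 is therefore expected to show a step of a number 1.7 percentage points higher from compound 2 to compound 3 (within the scatter), none beyond the scatter. The estimate for compound 3 is 35%, ranging from 20% to 50%.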

Compound 3, a percentage reported as inhibition, in the whole organism at one dose (the size of the read-out at that dose, not a potency): 36.7%
Beside the measured number, compound 3's estimate is 1.7 percentage points below it; low and high end bracket the measured number.
By their numbers in this assay, from the lowest: compounds 2, 3 and 1 (each within the scatter of the next).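

On the amide-type nitrogen, pyridin-3-yl in place of pyridin-2-yl gives a number 3.4 percentage points higher from compound 2 to compound 3 (within the scatter) in this assay and so does not separate the two groups. Pyridin-3-yl in place of 3-methylphenyl gives a number 5 percentage points lower from compound 1 to compound 3 (within the scatter) and thus, like the earlier swap, leaves all three groups at this place indistinguishable. Nothing available accounts for these numbers.

The compounds shown leave open whether a group of another kind on this nitrogen, such as a carboxylic acid, an amine or a longer alkyl chain, would shift the number in this assay beyond the scatter.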